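Uracil alkyl ethers: tert-butyl to isopropyl on the phenoxy ring

This account rests on a few compounds, and the source may have more. Where it says the series, first, only, none or still open, it means among the compounds named here.

Measured so far:
compound 1 `CC(C)(C)c1ccc(OCCCCCn2ccc(=O)[nH]c2=O)cc1`, 100000 nM in an ADME assay on HEL cells (Homo sapiens) for cytotoxicity, read by microscopy; a higher number here means that more compound is tolerated, a lower number that less compound is tolerated
compound 2 `O=c1ccn(CCCCCCCCOc2ccc(Br)cc2)c(=O)[nH]1`, >= 100000 nM
compound 3 `Cc1cc(C)cc(OCCCCCn2ccc(=O)[nH]c2=O)c1`, > 100000 nM

Among the compounds with values here, compound 1 holds the only full number in this assay; the values of compound 2 and compound 3 are limits of the assay. Compound 2 reaches a limit, (the limit of >= 100000 nM in this assay, at which 1 of the 3 values shown sits). Compound 3 likewise sits at a limit, (the limit of > 100000 nM in this assay, at which 1 of the 3 values shown sits). Compound 1 therefore stands at the top of what the assay can report, with nothing above it.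

Compound 4 `CC(C)c1ccc(OCCCCCn2ccc(=O)[nH]c2=O)cc1` is the next entry, not yet measured in this assay. Its change from compound 1 is hydrogen in place of methyl on a saturated chain carbon bound to an aromatic carbon and two saturated chain carbons; cut one bond further out, the same change reads tert-butyl to isopropyl. Within the data shown here, no measured step covers such a change. A step within the scatter, with no direction, is expected here, no change at the digits printed from compound 1 to compound 4 (within the scatter). Compound 4 is thus expected at 100000 nM, within 50000 nM to 200000 nM, most likely reported as a limit of the assay again.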

Compound 4, minimum cytotoxic concentration: 100000 nM
Beside the measured number, compound 4's estimate shows no gap at the digits printed; low and high end bracket the measured number.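

Tert-butyl to isopropyl, on a saturated chain carbon bound to an aromatic carbon and two saturated chain carbons, gives in this assay no change at the digits printed from compound 1 to compound 4 (within the scatter) as the only step yet available in this series. Hydrogen thus stands in place of methyl here with the two compounds within the scatter of each other, and both hold full numbers rather than limits.

Going by these compounds, whether a carboxylic acid or an amine on this phenoxy ring would also stay within the scatter remains open. No measured property in hand bears on this step.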